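Shortening the Chain: Propylamino to Methylamino

A few compounds are considered here, and "the series" means these few. Any claim that something is new, unique, unknown or untested is made for them only; others in the source may bear on it.

Compound 1 `CCCCNC(=N)NC(=N)Nc1ccc(Cl)cc1` and compound 2 `CCCNC(=N)NC(=N)Nc1ccc(Cl)cc1` share one core and differ only in the chain on the amine nitrogen. In a physicochemical assay for acid dissociation, compound 1 gives 10.8, and compound 2 gives 10.8. The step of no change at the digits printed from compound 1 to compound 2 (within the scatter) replaced methyl by hydrogen on a saturated chain carbon, three bonds along the chain from an amine nitrogen, and it left the read-out unchanged within the scatter. Compound 2 thus stands level with compound 1 at the digits shown.

Compound 3 `CNC(=N)NC(=N)Nc1ccc(Cl)cc1` has not yet been measured. Its difference from compound 2 is hydrogen in place of ethyl on a saturated chain carbon bound to an amine nitrogen, the same chain cut shorter, propylamino to methylamino. For the measured compounds named here, the only measured step that bears on it, from compound 1 to compound 2, shortened the same chain by a methyl and produced no change beyond the scatter. On that basis a further shortening is expected to produce a step of no change at the digits printed from compound 2 to compound 3 (within the scatter), none beyond the scatter. Compound 3 is therefore estimated at 10.8, with a range from 10.5 to 11.1.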

Compound 3, acid dissociation constant: 10.6
Compound 3: the middle estimate sits 0.20 log units above what was measured; the measured number falls inside the stated range.
By their numbers in this assay, from the lowest: compounds 3, 1 and 2 (each within the scatter of the next).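

In this assay the cut from propylamino to methylamino gives a number 0.20 log units lower from compound 2 to compound 3 (within the scatter) and so extends what had been seen only for the loss of a single methyl to the loss of a whole ethyl on a saturated chain carbon bound to an amine nitrogen. The wider comparison, hydrogen in place of propyl at that same place, gives a number 0.20 log units lower from compound 1 to compound 3 (within the scatter) and shows that even the largest change among these compounds stays inside the scatter, so that across compounds 1, 2 and 3 no step in chain length separates the read-out and none of the three goes against that reading. Why the read-out holds across these chains cannot be said, since no supporting measurement bears on it.

Going by these compounds, all three compounds carry plain unbranched chains on the amine nitrogen, so the behaviour of a longer chain, a branched isopropyl group or a cyclohexyl ring at this place remains open. Also open, on these data alone, is whether a chain bearing a carboxylic acid or a further amine would leave the read-out just as undisturbed, or whether such a group would produce a step beyond the scatter.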